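Bromo on the aromatic ring of the lactam core

The source may hold more compounds than are shown below. What is called first, only, known or untested is meant among the compounds shown, and "the series" means these compounds.

Compound 1 `C=C1CC(c2ccccc2)OC1=O`: 1400 nM
Compound 2 `C=C1CC(c2ccc(Br)cc2)OC1=O`: 1300 nM
Compound 3 `C=C1CC(c2ccccc2)N(C)C1=O`: > 50000 nM

In a functional assay on L1210 cells (Mus musculus) for cytotoxicity, with a stated time of 48 h (a lower number here means a stronger inhibitor, a higher number a weaker inhibitor), compound 1 gives 1400 nM and compound 2 gives 1300 nM. The change between them is bromo in place of hydrogen on an aromatic carbon, and the step of a 1.1-fold lower number from compound 1 to compound 2 (0.03 log units; within the scatter) lies within the scatter, so the two values cannot be told apart. Compound 3 has a different core; how the core of compound 3 differs from the core of compound 1 is not broken down here. In this assay compound 3 reaches only the limit > 50000 nM, the point (the limit of > 50000 nM in this assay, at which 1 of the 3 values shown sits), and so no number is known for it.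

Compound 4 `C=C1CC(c2ccc(Br)cc2)N(C)C1=O` is the not yet measured counterpart of compound 3 with bromo in place of hydrogen on an aromatic carbon. This is the same kind of change as from compound 1 to compound 2, but in compound 4 the bromo sits para to a group of 8 heavy atoms, while in compound 2 it sits para to a group of 7 heavy atoms. Since the step of a 1.1-fold lower number from compound 1 to compound 2 (0.03 log units; within the scatter) changed nothing beyond the scatter, compound 4 is expected to stay near the limit of compound 3, with an expected step of a number no higher from compound 3 to compound 4 (the limit leaves the size open). The estimate for compound 4 is 50000 nM, between 20000 nM and 100000 nM.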

Compound 4, half-maximal inhibitory concentration: > 50000 nM
Compound 4 gave a limit, no number; the forecaster's own chance of this, stated with the estimate: 80%; the middle value sits exactly at the limit.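

In this assay compound 4 gives > 50000 nM, which is a limit and not a number. Among the compounds shown here, compound 3 also stands at a limit, so no step from compound 3 to compound 4 can be read. The compounds shown leave open whether bromo in place of hydrogen on an aromatic carbon makes any difference on the core of compound 3.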